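The source may report more compounds than this note shows. Statements on the series, on what has been measured and on what is new or still open speak of the compounds shown alone.

In a functional assay on T47D cells (Homo sapiens) for inhibition, read by sulforhodamine B assay, with a stated time of 48 h (on this read-out lower numbers stand for stronger inhibition of growth and higher numbers for weaker inhibition of growth), compound 1 `Cc1cc(=O)oc2cc(N=C=[Se])ccc12` gives 3600 nM. Compound 2 `COC(=[Se])Nc1ccc2c(C)cc(=O)oc2c1` gives > 100000 nM, which is a limit of the assay and not a number. Compound 3 `CCOC(=[Se])Nc1ccc2c(C)cc(=O)oc2c1` differs from compound 2 by methyl in place of hydrogen on a saturated chain carbon bound to an oxygen on an unsaturated carbon, which turns methoxy into ethoxy. Within the data shown here, the only measured step, an at least 27-fold higher number from compound 1 to compound 2 (1.44 log units; beyond the scatter), was large but concerns a different change, so it does not test this one directly. With so small an edit, no step beyond the scatter is expected in this assay, and a further limit is quite possible. The expected step is a number no higher from compound 2 to compound 3 (the limit leaves the size open). Compound 3 is estimated at 100000 nM, within an expected range of 30000 nM to 300000 nM.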

Compound 3, concentration for 50% growth inhibition: > 100000 nM
Compound 3 gave a limit, no number; the forecaster's own chance of this, stated with the estimate: 65%; the middle value sits exactly at the limit.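

Lengthening methoxy to ethoxy gives no readable value in this assay: the result for compound 3 is a limit of the assay, not a number, so the step from compound 2 to compound 3 cannot be read. Replacing the group on the aromatic carbon of compound 1 with a longer one now gives the same picture with a second chain, with an at least 27-fold higher number from compound 1 to compound 3 (1.44 log units; beyond the scatter). Both chain compounds share one ceiling: the limit of > 100000 nM in this assay, at which 2 of the 3 values shown sit.

As far as these compounds go, whether methoxy and ethoxy differ at all remains open. Also open, from the compounds shown here alone, is whether an amine in that place, in place of the chain's oxygen, would give a measurable value.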